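Benzyloxycarbonyl in place of methoxy on the shared core

The compounds below may be only part of what the source reports. "The series", "measured", "known", "first", "only" and "open" are said of these compounds alone.

Measured so far in a functional assay on A549 cells (Homo sapiens) for antiproliferative activity, read by MTT assay, with a stated time of 48 h; a higher number here means a weaker inhibitor, a lower number a stronger inhibitor:
- compound 1 `O=C(OCc1ccccc1)c1ccc2[nH]c(-c3cn(-c4ccccc4)nc3-c3ccccc3)nc2c1` gives 19300 nM 
- compound 2 `COc1ccc(-c2nn(-c3ccccc3)cc2-c2nc3cc(OC)ccc3[nH]2)cc1` gives 22700 nM 

Compound 2 stands level with compound 1 in this assay, the two values lying within the scatter of each other. Compound 3 (`COc1ccc(-c2nn(-c3ccccc3)cc2-c2nc3cc(C(=O)OCc4ccccc4)ccc3[nH]2)cc1`) differs from compound 2 by one change, benzyloxycarbonyl in place of methoxy on an aromatic carbon. Among the measured compounds shown here, no measured step isolates this change. The expectation rests on compound 1, which also carries benzyloxycarbonyl and gives 19300 nM in this assay, so no step beyond the scatter is expected, in either direction. The expected move is a 1.3-fold lower number from compound 2 to compound 3 (0.13 log units; within the scatter) and it stays inside the scatter. For compound 3 the estimated value is 17000 nM with an expected range from 7000 nM up to 40000 nM on the numbers of this series.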

Compound 3, half-maximal inhibitory concentration: 11900 nM
Compound 3: middle estimate off by 1.4-fold (0.15 log units), on the high side; the range from low to high includes it.
By their numbers in this assay, from the lowest: compounds 3, 1 and 2 (each within the scatter of the next).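

In this assay the change from methoxy to benzyloxycarbonyl on this aromatic carbon now has a measured step of a 1.9-fold lower number from compound 2 to compound 3 (0.28 log units; within the scatter) and it stays within the scatter, so the larger group with its added six-membered aromatic ring brings no readable shift at this position. The second step of a 1.6-fold lower number from compound 1 to compound 3 (0.21 log units; within the scatter) belongs to methoxy in place of hydrogen on an aromatic carbon and also stays within the scatter, so with benzyloxycarbonyl present that methoxy brings no readable shift either. No measurement at hand bears on the reason for these values.

Going by these compounds, whether a carboxylic acid or a primary amide on the same aromatic carbon would give a step beyond the scatter remains open. Among the compounds shown here, with all three compounds level, the series so far holds no step that shows what this position requires.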